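Methylimidazole to methylpyrazole on one aromatic carbon

This account rests on a few compounds, and the source may have more. Where it says the series, first, only, none or still open, it means among the compounds named here.

In a physicochemical assay for lipophilicity, using the shake flask method, in phosphate buffer, measured as octanol-water partition, with a stated time of 30 min, at pH 7.4 (a higher number here means a more lipophilic compound, a lower number a more polar compound), compound 1 `Cn1cc(-c2cnc(NCc3c(F)ccc4c3CCO4)c3cn[nH]c(=O)c23)cn1` gives 2.7 and compound 2 `Cc1nccn1-c1cnc(NCc2c(F)ccc3c2CCO3)c2cn[nH]c(=O)c12` gives 2.1, the lower of the two numbers. Compound 3 `Cn1nccc1-c1cnc(NCc2c(F)ccc3c2CCO3)c2cn[nH]c(=O)c12` has not yet been measured. It holds the same atoms as compound 2, joined differently: 1-methyl-1H-pyrazol-5-yl in place of 2-methyl-1H-imidazol-1-yl on an aromatic carbon, with 1-methyl-1H-pyrazol-5-yl in place of 2-methyl-1H-imidazol-1-yl on an aromatic carbon.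

Among the measured compounds shown here, one measured step bears on this change: a number 0.60 log units lower from compound 1 to compound 2 (beyond the scatter), modest but beyond the scatter. That step also ends on 2-methyl-1H-imidazol-1-yl, starting from 1-methyl-1H-pyrazol-4-yl. For the measured compounds named here, the group entering compound 3 is a different methylpyrazole, and no measured compound carries it, so the step is only a partial guide. The nearest reference is compound 1 at 2.7 in the same measurement series. The estimated change is a number 0.40 log units higher from compound 2 to compound 3 (beyond the scatter), expected to recover most, but not all, of the measured step. For compound 3 the expected value is 2.5, with an estimated range from 2.1 to 2.9 in this assay.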

Compound 3, distribution coefficient: 2.6
For compound 3 the middle estimate is 0.10 log units below the measured one; the range from low to high includes it.
By their numbers in this assay, from the lowest: compound 2; then compounds 3 and 1 (each within the scatter of the next).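

At this aromatic carbon, the two methylpyrazoles cannot be told apart in this assay: the step is a number 0.10 log units lower from compound 1 to compound 3 (within the scatter) and so gives no ordering of 1-methyl-1H-pyrazol-4-yl and 1-methyl-1H-pyrazol-5-yl. Replacing 2-methyl-1H-imidazol-1-yl with 1-methyl-1H-pyrazol-5-yl gives a number 0.50 log units higher from compound 2 to compound 3 (beyond the scatter) and, read with a number 0.60 log units lower from compound 1 to compound 2 (beyond the scatter) for the other methylpyrazole, leaves 2-methyl-1H-imidazol-1-yl as the group that stands apart among these three, with no compound shown going against this. The separation appears between groups with the same counts of heavy atoms, hydrogen-bond donors and hydrogen-bond acceptors, so those counts do not distinguish compound 2 from compound 3, and no supporting measurement is available to account for the difference.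

The compounds shown leave open whether the separation follows the imidazole ring itself or its attachment through a ring nitrogen, a question that a 1-methyl-1H-imidazol-5-yl group at the same place would address. They also leave open how far the level shared by the two methylpyrazoles extends to an unmethylated pyrazole or a pyridine at this position.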